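The compounds below may be only part of what the source reports. "The series", "measured", "known", "first", "only" and "open" are said of these compounds alone.

Measured in a functional assay on HEL cells (Homo sapiens); a lower number here means that less compound is tolerated, a higher number that more compound is tolerated:
- compound 1 `O=S1(=O)N=C(OCc2ccccc2)c2ccccc2N1Cc1ccc(Cl)c(Cl)c1`: 200000 nM
- compound 2 `O=C1c2ccccc2N(Cc2ccccc2Cl)S(=O)(=O)N1Cc1ccccc1`: 200000 nM
- compound 3 `O=C1c2ccccc2N(Cc2ccc(Cl)cc2)S(=O)(=O)N1Cc1ccc(Cl)cc1`: > 50000 nM, a limit of this assay, not a number

Compound 1 stands level with compound 2 at the digits shown; the two values lie within the scatter of each other, so no order between them is claimed. Compound 3 is reported only at the limit of > 50000 nM in this assay, at which 1 of the 3 values shown sits, which is a limit and not a measured number, so it is not placed against the other two.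

The next compound is compound 4 `O=S1(=O)N=C(OCc2ccccc2)c2ccccc2N1Cc1ccccc1`, which is to be measured in this assay. It differs from compound 1 in one place: phenyl in place of 3,4-dichlorophenyl on a saturated chain carbon bound to a sulfonamide nitrogen in a ring. For the measured compounds named here, no measured pair in the set tracks this difference, so the expected size of the step cannot be read from a measured step.

Given that compound 1 gives 200000 nM and compound 2 gives 200000 nM, both high tolerated concentrations, the expectation is that compound 4 stays near that level, with a step from no change at the digits printed from compound 1 to compound 4 (within the scatter) that is not expected to exceed the scatter. Compound 4 is therefore estimated at 200000 nM, with a range from 100000 nM to 400000 nM.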

Compound 4, minimum cytotoxic concentration: 200000 nM
For compound 4 middle estimate and measured number coincide at the digits printed; the range from low to high includes it.
By their numbers in this assay, from the lowest: compounds 1, 2 and 4 (each within the scatter of the next).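

In this assay, for the compounds shown here, phenyl in place of 3,4-dichlorophenyl on a saturated chain carbon bound to a sulfonamide nitrogen in a ring gives no change at the digits printed from compound 1 to compound 4 (within the scatter), the first step that can be read at this position. For this pair, then, the minimum cytotoxic concentration does not depend on the two chlorine atoms, and the unsubstituted benzyl keeps compound 4 level with compound 1. Nothing among the available data bears on why the value holds across this change.

Going by these compounds, whether an amine or a carboxylic acid on that phenyl, or a longer chain in place of benzyl, would shift the value in this assay remains open. On these data alone, a single chlorine on this ring on the core of compound 1 is also open, as one step cannot show whether the level holds across other substituents at this position.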